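The source may hold more compounds than are shown below. What is called first, only, known or untested is meant among the compounds shown, and "the series" means these compounds.

Measured so far in a functional assay for inhibition of sodium/hydrogen exchanger (Oryctolagus cuniculus); a lower number here means a stronger inhibitor, a higher number a weaker inhibitor:
- compound 1 `CCCc1cc(C)c(C(=O)N=C(N)N)cc1S(C)(=O)=O`: 5.7 nM
- compound 2 `Cc1cc(OCc2ccccc2)c(S(C)(=O)=O)cc1C(=O)N=C(N)N`: 28 nM

Within the data shown here, compound 2 stands highest of the two numbers in this assay; its nearest neighbour is compound 1, and the only step recorded is a 4.9-fold higher number from compound 1 to compound 2 (0.69 log units; beyond the scatter), a modest worsening on going to benzyloxy in place of propyl on an aromatic carbon.

Compound 3 `Cc1cc(N2CCCC(O)C2)c(S(C)(=O)=O)cc1C(=O)N=C(N)N` is next to be measured. The change from compound 2 is 3-hydroxypiperidin-1-yl in place of benzyloxy on an aromatic carbon.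

Among the measured compounds shown here, no measured step bears directly on this change: the single recorded step swaps one aromatic substituent for another at the same place, and it is modest in size. Two substituents at this position, propyl and benzyloxy, have so far both given tight inhibition, which suggests the position tolerates variation, while the direction for a 3-hydroxypiperidin-1-yl group cannot be read from the data. The expected step is therefore a 1.1-fold higher number from compound 2 to compound 3 (0.03 log units; within the scatter), small in either direction, and the estimate for compound 3 in this assay is 30 nM, with a range from 8 nM to 120 nM.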

Compound 3, half-maximal inhibitory concentration: 30 nM
Estimate against measurement, compound 3: no gap at the digits printed; low and high end bracket the measured number.
By their numbers in this assay, from the lowest: compound 1; then compounds 2 and 3 (each within the scatter of the next).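

In this assay, the place ortho to a methylsulfonyl group accepts 3-hydroxypiperidin-1-yl and benzyloxy with no difference beyond the scatter, a 1.1-fold higher number from compound 2 to compound 3 (0.03 log units; within the scatter), even though the entering group swaps an aromatic ring of carbon only for a non-aromatic ring with a hetero atom and adds a hydrogen-bond donor. Measured against propyl, the same group gives a 5.3-fold higher number from compound 1 to compound 3 (0.72 log units; beyond the scatter), so compound 1 keeps the lowest number of the three, while compounds 2 and 3, the two with a ring-bearing substituent at this place, sit level with each other. No supporting data are available to explain either the level result for the two ring-bearing groups or their distance from propyl.

Still open, from the compounds shown here alone, is whether the hydroxyl of the 3-hydroxypiperidin-1-yl group plays any part in this result, a question that an unsubstituted piperidin-1-yl group at the same place would address directly. Also open, going by these compounds, is how a longer chain such as butyl, or a small open-chain amine such as dimethylamino, would compare with propyl at this place on the same core.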